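The source may hold more compounds than are shown below. What is called first, only, known or untested is meant among the compounds shown, and "the series" means these compounds.

Measured in a functional assay on HCT-116 cells (Homo sapiens), read by MTT assay, with a stated time of 72 h; a lower number here means a stronger inhibitor, a higher number a weaker inhibitor:
- compound 1 `COc1ncnc2c1c(-c1cc3ccccc3o1)cn2[C@@H]1O[C@H](CO)[C@@H](O)[C@H]1O`: 14500 nM
- compound 2 `CSc1ncnc2c1c(-c1ccsc1)cn2[C@@H]1O[C@H](CO)[C@@H](O)[C@H]1O`: > 20000 nM
- compound 3 `CNc1ncnc2c1c(-c1ccco1)cn2[C@@H]1O[C@H](CO)[C@@H](O)[C@H]1O`: 440 nM

The entry for compound 2 is a limit of the assay and not a number. Among the measured compounds shown here, only two true numbers therefore exist. Compound 3, at 440 nM, holds the lower of them, and compound 1, at 14500 nM, lies higher, well beyond the scatter.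

Compound 4 `CNc1ncnc2c1c(-c1ccccc1)cn2[C@@H]1O[C@H](CO)[C@@H](O)[C@H]1O` has not yet been measured in this assay. It differs from compound 3 in one place, with phenyl in place of furan-2-yl on an aromatic carbon.

For the measured compounds named here, no measured pair isolates a change of this kind, since the three measured compounds differ from one another in more than one place, so the expectation is a loose one. The low number of compound 3, 440 nM, is the only one of its kind here and is set against weaker neighbours, so a move towards a weaker inhibitor seems more likely than a gain. The estimated step is a 5.7-fold higher number from compound 3 to compound 4 (0.75 log units; beyond the scatter), expected to lie beyond the scatter. For compound 4 the estimate is 2500 nM, with an expected range from 500 nM to 15000 nM.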

Compound 4, half-maximal inhibitory concentration: > 100000 nM
Compound 4 was reported as a limit (the forecaster's own chance of this, stated with the estimate: 15%); middle value at least 40-fold (1.60 log units) from the limit.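

In this assay, compound 3 and compound 4 form the only pair shown that differs in one place, and phenyl in place of furan-2-yl on an aromatic carbon gives an at least 220-fold higher number from compound 3 to compound 4 (2.35 log units; beyond the scatter). The entry for compound 4 is a limit of the assay and not a number: the limit of > 100000 nM in this assay, at which 1 of the 4 values shown sits. With the rest of the structure shared, the exchange of a five-membered aromatic ring with 1 hetero atom for a six-membered aromatic ring of carbon only is therefore far from neutral at this position, although nothing shown gives a reason for it.

From the compounds shown here alone, whether the furan-2-yl group itself is required remains open, as thiophen-2-yl or pyrrol-2-yl at this carbon could keep or lose the inhibition seen with compound 3. Compound 1 and compound 2 differ from compound 3 in more than one place, so they do not settle this, and the effect of a methyl group or a chlorine atom here is also unknown.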